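Amidine side-chain variation on the shared core

The source may report more compounds than this note shows. Statements on the series, on what has been measured and on what is new or still open speak of the compounds shown alone.

Two compounds of the series have been run in a functional assay on NPC-TW01 cells (Homo sapiens) for inhibition, read by MTT assay, with a stated time of 72 h; a lower number here means a stronger inhibitor of growth, a higher number a weaker inhibitor of growth. Compound 1 `CN(C)/C=N/c1c(C=O)c(-c2ccc(Cl)cc2)nn1-c1ccccc1` gives 8100 nM. Compound 2 `CN/C=N/c1cc(-c2ccccc2)nn1-c1ccccc1` is reported in this assay only as a limit, > 50000 nM, so no number is known for it. Compound 2 therefore sits at the limit of > 50000 nM in this assay, at which 1 of the 2 values shown sits. Among the compounds with values here, the pair with compound 1 shows only that compound 1 has a number where compound 2 has none; no step between the two is counted, since they differ in more than one place.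

Compound 3 `CN/C(C)=N/c1cc(-c2ccccc2)nn1-c1ccccc1` is the next member to be measured. It differs from compound 2 by a group of 5 heavy atoms (3 carbon, 2 nitrogen; no ring) in place of a group of 4 heavy atoms (2 carbon, 2 nitrogen; no ring), on an aromatic carbon. Within the data shown here, no measured step of this kind exists, so its size cannot be read from the numbers. With compound 2 standing only at a limit, no move beyond the scatter in this assay is expected in either direction, and a further limit is the likeliest outcome. Compound 3 is estimated at 60000 nM, within 20000 nM to 200000 nM. The expected step is a step that the limit leaves unreadable from compound 2 to compound 3.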

Compound 3, concentration for 50% growth inhibition: > 50000 nM
Compound 3: a limit, no number; the forecaster's own chance of this, stated with the estimate: 80%; the middle value is on the limit's open side.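

In this assay, compound 2 and compound 3 are both reported only as limits, so no step between them can be read: the limit of > 50000 nM in this assay, at which 2 of the 3 values shown sit.

On these data alone, whether a group of 5 heavy atoms (3 carbon, 2 nitrogen; no ring) in place of a group of 4 heavy atoms (2 carbon, 2 nitrogen; no ring) shifts growth inhibition at all remains open.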